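Adding a second chloro to compound 2

The source may report more compounds than this note shows. Statements on the series, on what has been measured and on what is new or still open speak of the compounds shown alone.

Of the compounds shown here, three with a shared core have been measured in a functional assay on Jurkat cells (Homo sapiens) for antiproliferative activity, read by MTT assay; a lower number here means a stronger inhibitor, a higher number a weaker inhibitor. Compound 1 (`COc1cc2c(cc1OC)C(=O)/C(=C/c1cccc(C)c1)C2`), with methyl on an aromatic carbon, gives 1800 nM. Compound 2 (`COc1cc2c(cc1OC)C(=O)/C(=C/c1cccc(Cl)c1)C2`), with chloro in place of that methyl, gives 8000 nM. Compound 3 (`COc1cccc(/C=C2\Cc3cc(OC)c(OC)cc3C2=O)c1`), with methoxy there, gives 12800 nM.

The two steps away from methyl are modest and beyond the scatter: a 4.4-fold higher number from compound 1 to compound 2 (0.65 log units; beyond the scatter) and a 7.1-fold higher number from compound 1 to compound 3 (0.85 log units; beyond the scatter). The remaining step, a 1.6-fold higher number from compound 2 to compound 3 (0.20 log units; within the scatter), lies within the scatter. Compound 2 therefore stands level with compound 3, and both sit on the weaker side of compound 1, which has the lowest number of the three.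

Compound 4 (`COc1cc2c(cc1OC)C(=O)/C(=C/c1cc(Cl)cc(Cl)c1)C2`) is compound 2 with one further change: chloro in place of hydrogen on an aromatic carbon. Within the data shown here, no measured step replaces a hydrogen, since all three exchange one group for another at a single place. They give only a rough scale, from within the scatter up to modest, and they give no direction for this change. No step beyond the scatter is therefore expected in this assay, though a modest step either way remains possible.

The estimate corresponds to a 1.1-fold higher number from compound 2 to compound 4 (0.05 log units; within the scatter), an expected step within the scatter. For compound 4 the expected value is 9000 nM, with an estimated range of 3000 nM to 30000 nM.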

Compound 4, half-maximal inhibitory concentration: 2000 nM
For compound 4 the middle estimate is 4.5-fold (0.65 log units) above the measured one; the whole stated range lies above it.
By their numbers in this assay, from the lowest: compounds 1 and 4 (each within the scatter of the next); then compounds 2 and 3 (each within the scatter of the next).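

In this assay, among these compounds, the step of a 4.0-fold lower number from compound 2 to compound 4 (0.60 log units; beyond the scatter) is the first that fills a hydrogen position on the aromatic ring rather than exchanging one group for another, and it shows that this place, meta to a chloro group, is not neutral. Among the compounds shown here, its direction is also new: the steps among the earlier compounds showed chloro only as a loss against methyl, as in a 4.4-fold higher number from compound 1 to compound 2 (0.65 log units; beyond the scatter), whereas a further chloro on the same ring of compound 2 moves the number the other way, by a modest step beyond the scatter. The data shown offer no measured basis for explaining this step.

It remains open whether this gain belongs to chloro itself or to any group at this place, since a single added chloro is the only change shown here; a methyl, a methoxy, an amine or a carboxylic acid there would separate the two readings. Also open, from the compounds shown here alone, is whether the same addition would lower the number for compound 1 or compound 3, whose rings carry a different first group.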